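The compounds below may be only part of what the source reports. "The series", "measured", "known", "first", "only" and "open" are said of these compounds alone.

Measured in a functional assay on the whole organism with Rattus norvegicus as the target; on this read-out lower numbers stand for an effect already at smaller amounts and higher numbers for an effect only at larger amounts of compound:
- compound 1 `CCOC(=O)C(=O)Nc1cccc(N(C)C)c1C#N`: 0.2 mg/kg
- compound 2 `CCOC(=O)C(=O)Nc1ccc(N(C)C)cc1C#N`: 1 mg/kg
- compound 3 `CCOC(=O)C(=O)Nc1cccc(N)c1C#N`: 0.05 mg/kg

Compound 3 has the lowest number of the three, with compound 1 nearest and compound 2 furthest. Compound 4 `CCNc1cccc(NC(=O)C(=O)OCC)c1C#N` is the next to be read, and its change is ethyl in place of hydrogen on a nitrogen on an aromatic ring. For the measured compounds named here, one measured step bears on this: a 4.0-fold lower number from compound 1 to compound 3 (0.60 log units; beyond the scatter), with amino in place of dimethylamino on an aromatic carbon. Read backwards, it suggests a higher number once that nitrogen is substituted, although no measurement isolates ethyl. A similar or smaller rise in this assay is therefore expected, and the expected change is a 2.4-fold higher number from compound 3 to compound 4 (0.38 log units; beyond the scatter) overall. Compound 4 is estimated at 0.12 mg/kg, with an expected range from 0.04 mg/kg to 0.4 mg/kg.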

Compound 4, dose for half-maximal effect: 0.03 mg/kg
The estimate for compound 4 lay 4.0-fold (0.60 log units) above the measured number; measured number below the stated range.
By their numbers in this assay, from the lowest: compounds 4 and 3 (each within the scatter of the next); then compound 1; then compound 2.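

In this assay, ethyl on this nitrogen shows a 1.7-fold lower number from compound 3 to compound 4 (0.22 log units; within the scatter), so the amino and ethylamino compounds cannot be told apart. Ethylamino in place of dimethylamino gives a 6.7-fold lower number from compound 1 to compound 4 (0.82 log units; beyond the scatter), so substitution on this nitrogen does not by itself carry the higher number of compound 1.

Open, as far as these compounds go, is whether propyl or a longer chain on this nitrogen stays level with ethyl in this assay, and whether diethylamino returns towards compound 1. No measured evidence accounts for the difference between ethylamino and dimethylamino.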